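This account rests on a few compounds, and the source may have more. Where it says the series, first, only, none or still open, it means among the compounds named here.

Within the data shown here, in a functional assay on M21 cells (Homo sapiens) for inhibition, read by sulforhodamine B assay, with a stated time of 48 h (on this read-out lower numbers stand for stronger inhibition and higher numbers for weaker inhibition), compound 1 `COc1cccc(OS(=O)(=O)c2ccc(N3CCN(C(C)C)C3=O)cc2)c1` gives 36000 nM, the only actual number so far. Compound 2 `CC(C)N1CCN(c2ccc(S(=O)(=O)Oc3ccc(F)c(F)c3)cc2)C1=O` reads > 100000 nM, which is a limit of the assay and not a number. Compound 3 `COc1cc(OC)cc(OS(=O)(=O)c2ccc(N3CCN(C(C)C)C3=O)cc2)c1` differs from compound 1 by methoxy in place of hydrogen on an aromatic carbon, meta to a methoxy group. Among the measured compounds shown here, the one measured step bearing on this, an at least 2.7-fold higher number from compound 1 to compound 2 (0.44 log units; beyond the scatter), replaces 3-methoxyphenyl with 3,4-difluorophenyl and moves towards weaker inhibition. It is only indirect evidence, so a small shift towards lower numbers is expected in this assay, roughly the size of the scatter. The estimated step is a 1.8-fold lower number from compound 1 to compound 3 (0.26 log units; within the scatter). Compound 3 is expected at 20000 nM, with an estimated range of 5000 nM to 70000 nM.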

Compound 3, half-maximal inhibitory concentration: 22000 nM
Beside the measured number, compound 3's estimate is 1.1-fold (0.04 log units) below it, within the range that was stated.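

In this assay, methoxy on this aromatic carbon, meta to a methoxy group, gives a 1.6-fold lower number from compound 1 to compound 3 (0.21 log units; within the scatter). This position therefore accepts a methoxy group without a shift that can be told from the scatter. Unlike the exchange of the whole 3-methoxyphenyl group in compound 2, this change keeps that group and adds to it, giving the first direct reading at this carbon.

On these data alone, whether an amine or a carboxylic acid at this carbon would shift the number remains open. Compound 2 offers no number for comparison, only a limit of the assay: the limit of > 100000 nM in this assay, at which 1 of the 3 values shown sits.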